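The source may hold more compounds than are shown below. What is called first, only, known or untested is meant among the compounds shown, and "the series" means these compounds.

Compounds measured so far in a functional assay on aorta for antagonist activity at Alpha-1D adrenergic receptor (Rattus norvegicus); on this read-out lower numbers stand for tighter binding and higher numbers for weaker binding:
compound 1, `CCOc1ccccc1N1CCN(CCCNc2ncccc2C(=O)N(C)C)CC1`, 7.94 nM
compound 2, `Cc1ccccc1N1CCN(CCCNc2ncccc2C(=O)N(C)C)CC1`, 10 nM

Compound 2 and compound 1 differ only at the aromatic carbon bearing methyl or ethoxy, and the step of a 1.3-fold higher number from compound 1 to compound 2 (0.10 log units; within the scatter) is within the scatter, so on the numbers shown compound 2 stands together with compound 1 rather than apart from it; there is no second number for comparison beyond that.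

Compound 3, `CC(C)c1ccccc1N1CCN(CCCNc2ncccc2C(=O)N(C)C)CC1`, follows from compound 2 by isopropyl in place of methyl on an aromatic carbon. Among the compounds with values here, the only measured step that bears on this position is the one from compound 1 to compound 2, an exchange of ethoxy for methyl at the same aromatic carbon, and it stayed within the scatter. That is one step only, and it does not cover isopropyl, so the expectation rests on thin ground. Taken at face value, the position tolerated two different groups without a change beyond the scatter, and the step of a 1.2-fold higher number from compound 2 to compound 3 (0.08 log units; within the scatter) is therefore expected to be small, with no direction settled. In this assay compound 3 is estimated at 12 nM, within 5 nM to 30 nM.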

Compound 3, dissociation constant: 63.1 nM
Compound 3: middle estimate off by 5.3-fold (0.72 log units), on the low side; measured number above the stated range.
By their numbers in this assay, from the lowest: compounds 1 and 2 (each within the scatter of the next); then compound 3.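

In this assay, this aromatic carbon, ortho to a large group, no longer reads as indifferent to its substituent: methyl and ethoxy stood within the scatter of each other, but isopropyl gives a 6.3-fold higher number from compound 2 to compound 3 (0.80 log units; beyond the scatter) and a 7.9-fold higher number from compound 1 to compound 3 (0.90 log units; beyond the scatter). The tolerance suggested by the earlier pair therefore does not extend to every group at this carbon, and a change from 2-methylphenyl to 2-isopropylphenyl, with 1 heavy atom leaving and 3 entering, is enough to produce a step beyond the scatter. No available measurement accounts for the separation of isopropyl from methyl and ethoxy.

The three compounds leave open how the number changes across intermediate and larger groups at this carbon, such as ethyl, methoxy or tert-butyl, and therefore whether isopropyl marks a sharp break or one point on a gradual trend. They also leave open whether the step from methyl to isopropyl would recur if the dimethyl amide of the shared core were replaced by a carboxylic acid or a primary amide.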